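A Methyl Added to a Series That Shows Only Limits

This account rests on a few compounds, and the source may have more. Where it says the series, first, only, none or still open, it means among the compounds named here.

The study follows four closely related compounds in a functional assay on RAW264.7 cells (Mus musculus) for inhibition, with stated times of 2 h and 24 h; a lower number here means a stronger inhibitor, a higher number a weaker inhibitor. Compound 1 `COc1ccc([C@@H]2c3c(OC)cc(OC)cc3/C(=C/c3ccccc3)[C@H]2c2cc(OC)cc(OC)c2)cc1` carries a plain phenyl group on its exocyclic double bond, and compound 2 `COc1ccc([C@@H]2c3c(OC)cc(OC)cc3/C(=C/c3ccc(C)cc3)[C@H]2c2cc(OC)cc(OC)c2)cc1` differs from it by methyl in place of hydrogen on an aromatic carbon. Compound 3 `COc1ccc([C@@H]2c3c(OC)cc(OC)cc3C(C(O)c3ccccc3)[C@H]2c2cc(OC)cc(OC)c2)cc1` belongs to a second core; how that core differs from the core of compound 1 is not broken down here. For the measured compounds named here, compound 4 `COc1ccc([C@@H]2c3c(OC)cc(OC)cc3C(C(O)c3ccc(C)cc3)[C@H]2c2cc(OC)cc(OC)c2)cc1` is the one compound still to be measured, and it differs from compound 3 by methyl in place of hydrogen on an aromatic carbon. The place of the change is the same word for word in both pairs, so the two changes are of the same kind.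

In this assay compound 1 gives only a limit, > 200000 nM. Compound 2 likewise gives only a limit, > 200000 nM. Compound 3 gives a limit as well, > 200000 nM. The step that the two limits leave unreadable from compound 1 to compound 2 therefore cannot be sized; the two limits leave it unreadable. The whole picture rests on (the limit of > 200000 nM in this assay, at which 3 of the 3 values shown sit), where every value of the study so far sits.

On that footing compound 4 is expected to behave like its neighbours, with an estimate of 300000 nM and a range from 150000 nM to 1000000 nM, most likely reported again as a limit rather than a number. The expected step that the limit leaves unreadable from compound 3 to compound 4 is accordingly small, resting on the unreadable step between compound 1 and compound 2.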

Compound 4, half-maximal inhibitory concentration: 26500 nM
Estimate against measurement, compound 4: 11-fold (1.05 log units) above; measured number outside the range, below it.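

In this assay, methyl in place of hydrogen on an aromatic carbon gives an at least 7.5-fold lower number from compound 3 to compound 4 (0.87 log units; beyond the scatter), a step beyond the scatter, so on the core of compound 3 this change goes with a stronger inhibitor. On the core of compound 1 the same change cannot be read, as compound 1 and compound 2 each stand only as a limit, so the series shows neither that the change carries over from one core to the other nor that it fails to do so. The gain on the core of compound 3 comes from a single pair, its size is only a lower bound, and the comparison between the two cores has little to stand on: the limit of > 200000 nM in this assay, at which 3 of the 4 values shown sit.

The compounds shown leave open how far the number of compound 4 could move if the methyl were replaced at the same place on the six-membered aromatic ring by a longer chain such as ethyl, by an amine or by a carboxylic acid. They also leave open whether any such group would bring the core of compound 1 to a readable number in this assay.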